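A few compounds are considered here, and "the series" means these few. Any claim that something is new, unique, unknown or untested is made for them only; others in the source may bear on it.

Compound 3 `COc1ccc([C@H]2CC(=O)N(c3cccc(N)c3C)C2)cc1OC1CCCC1` was tested in a functional assay on HEK293 cells (Homo sapiens) for cytotoxicity; on this read-out higher numbers stand for lower toxicity in this test and lower numbers for higher toxicity in this test. There compound 3 gives > 10000 nM, which is a limit of the assay rather than a number. Compound 1 `COc1ccc([C@H]2CC(=O)N(Cc3cccc(C#N)c3)C2)cc1OC1CCCC1` gives > 10000 nM, also a limit. Compound 2 `COc1ccc([C@H]2CC(=O)N(C(C)=O)C2)cc1OC1CCCC1` gives > 10000 nM, again a limit. Compound 3 thus stands where every value sits so far: the limit of > 10000 nM in this assay, at which 3 of the 3 values shown sit. Compound 4 `COc1ccc([C@H]2CC(=O)N(c3ccc(C)cc3)C2)cc1OC1CCCC1` differs from compound 3 in one place: 4-methylphenyl in place of 3-amino-2-methylphenyl on an amide-type nitrogen in a ring. The steps measured so far, a step that the two limits leave unreadable from compound 1 to compound 2, a step that the two limits leave unreadable from compound 1 to compound 3 and a step that the two limits leave unreadable from compound 2 to compound 3, each exchange the group on an amide-type nitrogen in a ring, yet none has a readable size, so they point in no direction. Compound 4 is expected to stay at the limit, with a step that the limit leaves unreadable from compound 3 to compound 4 not readable beyond the scatter. Compound 4 is therefore estimated at 15000 nM, between 7000 nM and 40000 nM.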

Compound 4, half-maximal cytotoxic concentration: > 10000 nM
Compound 4 ended at the assay's limit (the forecaster's own chance of this, stated with the estimate: 85%); the middle value lies beyond the limit too.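

In this assay, the steps from compound 1, compound 2 and compound 3 to compound 4 cannot be read, as all four compounds share one limit: the limit of > 10000 nM in this assay, at which 4 of the 4 values shown sit. The compounds shown leave open whether any group on the amide-type nitrogen would give a readable value.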